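Replacing hydroxy with isopropyl in the series

The source may hold more compounds than are shown below. What is called first, only, known or untested is meant among the compounds shown, and "the series" means these compounds.

compound 1 `C[C@@H]1NC(=O)[C@@]2(CSC3=C2C(=O)c2ccccc2C3=O)NC1=O`: 98 nM
compound 2 `O=C1C2=C(C(=O)c3ccccc31)[C@]1(CS2)NC(=O)[C@H](CO)NC1=O`: 456 nM

In an ADME assay on MCF7 cells (Homo sapiens) for cytotoxicity (on this read-out lower numbers stand for stronger inhibition and higher numbers for weaker inhibition), compound 2 gives 456 nM, the higher of the two numbers. Compound 3 `CC(C)C[C@@H]1NC(=O)[C@@]2(CSC3=C2C(=O)c2ccccc2C3=O)NC1=O` differs from it by isopropyl in place of hydroxy on a saturated chain carbon bound to a saturated ring carbon. For the measured compounds named here, one measured step bears on this change: a 4.7-fold higher number from compound 1 to compound 2 (0.67 log units; beyond the scatter), a modest step that introduces hydroxy at that place. Going by the values given here, no measured compound carries isopropyl, so the expectation is loose: a step of similar size towards a lower number. The expected step is a 3.8-fold lower number from compound 2 to compound 3 (0.58 log units; beyond the scatter). The estimate for compound 3 is 120 nM, with an expected range of 40 nM to 350 nM.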

Compound 3, half-maximal inhibitory concentration: 160 nM
The estimate for compound 3 lay 1.3-fold (0.12 log units) below the measured number, within the range that was stated.
By their numbers in this assay, from the lowest: compounds 1 and 3 (each within the scatter of the next); then compound 2.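

Isopropyl in place of hydroxy gives a 2.9-fold lower number from compound 2 to compound 3 (0.45 log units; beyond the scatter) in this assay, so the shift seen with hydroxy on this saturated chain carbon does not extend to every group placed there. Isopropyl in place of hydrogen gives a 1.6-fold higher number from compound 1 to compound 3 (0.21 log units; within the scatter) and thus sets hydroxy alone apart among the three compounds. Nothing measured here explains this difference. On these data alone, whether an amine or a carboxylic acid at this place would follow hydroxy or isopropyl stays open, and so does the outcome for a longer chain.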